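The compounds below may be only part of what the source reports. "The series", "measured", "known", "first", "only" and "open" are said of these compounds alone.

In an ADME assay on CEMx174 cells (Homo sapiens) for cytotoxicity (on this read-out lower numbers stand for higher toxicity in this test and higher numbers for lower toxicity in this test), compound 1 `CCC1=C(C(=O)OCC2CCCCC2)C(c2cccc(O)c2)NC(=O)N1` gives > 10000 nM, which is a limit of the assay and not a number. Compound 2 `CCCC1=C(C(=O)OCC2CCCCC2)C(c2cccc(O)c2)NC(=O)N1` gives > 10000 nM, which is also a limit. That is the limit of > 10000 nM in this assay, at which 2 of the 2 values shown sit, so compound 1 has no readable number to stand on and no neighbour to be ranked against.

Compound 3 `CCC1=C(C(=O)OCC2CCCCC2)C(c2ccc(O)cc2)NC(=O)N1` keeps the core of compound 1 and moves only the hydroxyl group, with 4-hydroxyphenyl in place of 3-hydroxyphenyl on a saturated ring carbon. The change is 4-hydroxyphenyl in place of 3-hydroxyphenyl on a saturated ring carbon.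

For the measured compounds named here, the only measured step is a step that the two limits leave unreadable from compound 1 to compound 2. It lies on the chain and not on the hydroxyphenyl group, and it has no readable size, so it offers only weak guidance. Going by the values given here, no measured step covers the new change directly. With nothing pointing either way, no step beyond the scatter is expected in this assay, and another limit is the likeliest report. The expected step is a step that the limit leaves unreadable from compound 1 to compound 3. For compound 3 the estimated value is 20000 nM, within an expected range from 10000 nM to 50000 nM.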

Compound 3, half-maximal cytotoxic concentration: > 10000 nM
Compound 3 was reported as a limit; the forecaster's own chance of this, stated with the estimate: 85%; the middle value lies beyond the limit too.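

Compound 1 and compound 3 are both reported only as limits in this assay, so no step can be read for 4-hydroxyphenyl in place of 3-hydroxyphenyl: the limit of > 10000 nM in this assay, at which 3 of the 3 values shown sit.

The compounds shown leave open whether 3-hydroxyphenyl and 4-hydroxyphenyl differ at all in this assay, and what number any of these compounds would give beyond the limit.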